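A few compounds are considered here, and "the series" means these few. Any claim that something is new, unique, unknown or untested is made for them only; others in the source may bear on it.

Compound 1 `CC1=CC[C@H](C(C)(C)NC(=S)N/N=C/c2ccccc2)CC1`: in a functional assay on PC-3 cells (Homo sapiens) for inhibition, read by sulforhodamine B assay, with a stated time of 48 h (on this read-out lower numbers stand for stronger inhibition of growth and higher numbers for weaker inhibition of growth), compound 1 gives 5700 nM.
Compound 2 `CC1=CC[C@H](C(C)(C)NC(=S)N/N=C/c2ccccc2O)CC1`: compound 2 gives 900 nM.
Compound 3 `CC1=CC[C@H](C(C)(C)NC(=S)N/N=C/c2ccccc2Cl)CC1`: compound 3 gives 700 nM.

Compound 3 has the lowest of the three numbers, but compound 2 sits within the scatter of it, so the two cannot be ordered; only compound 1 stands clearly apart, as the step of an 8.1-fold lower number from compound 1 to compound 3 (0.91 log units; beyond the scatter) shows. The unmeasured compound 4 `CC1=CC[C@H](C(C)(C)NC(=S)N/N=C/c2ccccc2[N+](=O)[O-])CC1` differs from compound 3 in one place: nitro in place of chloro on an aromatic carbon. Within the data shown here, two measured steps bear on this. Putting a group on that aromatic carbon gave a 6.3-fold lower number from compound 1 to compound 2 (0.80 log units; beyond the scatter) and an 8.1-fold lower number from compound 1 to compound 3 (0.91 log units; beyond the scatter), while exchanging one such group for another gave only a 1.3-fold lower number from compound 2 to compound 3 (0.11 log units; within the scatter). Both substituted compounds thus fall close together, and the exchange to nitro is expected to behave likewise, with no step beyond the scatter in either direction. Compound 4 is therefore expected to give about 800 nM, with a range from 300 nM to 2500 nM. For compound 4 the expected step is a 1.1-fold higher number from compound 3 to compound 4 (0.06 log units; within the scatter), within the scatter.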

Compound 4, concentration for total growth inhibition: 6400 nM
The estimate for compound 4 lay 8.0-fold (0.90 log units) below the measured number; measured number outside the range, above it.
By their numbers in this assay, from the lowest: compounds 3 and 2 (each within the scatter of the next); then compounds 1 and 4 (each within the scatter of the next).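

The result shows that in this assay not every group on this aromatic carbon, ortho to a large group, goes with a lower number than hydrogen does. Nitro in place of chloro gives a 9.1-fold higher number from compound 3 to compound 4 (0.96 log units; beyond the scatter) and nitro in place of hydroxy gives a 7.1-fold higher number from compound 2 to compound 4 (0.85 log units; beyond the scatter) while nitro in place of hydrogen gives only a 1.1-fold higher number from compound 1 to compound 4 (0.05 log units; within the scatter) and so leaves no change that can be read. The exchange of one group for another at this carbon can therefore be as large as the step from hydrogen to chloro, though nothing given here accounts for the difference between the groups.

From the compounds shown here alone, whether an amine, a methoxy group or a carboxylic acid at this carbon would fall with chloro and hydroxy or with nitro stays open. So does whether nitro on another carbon of the same ring would give a different number.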